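Working notes: a third aryl group on the shared core

The source may report more compounds than this note shows. Statements on the series, on what has been measured and on what is new or still open speak of the compounds shown alone.

Among the measured compounds shown here, in a functional assay on KB cells (Homo sapiens) for antiproliferative activity, read by sulforhodamine B assay, with a stated time of 3 days (a higher number here means that more compound is needed for the effect, a lower number that less compound is needed), compound 1 `CCC1=C(O)c2c(oc(-c3ccccc3C)cc2=O)C(CC)(CC)C1=O` gives 40.9 uM and compound 2 `CCC1=C(O)c2c(oc(-c3ccc(C)c(Cl)c3)cc2=O)C(CC)(CC)C1=O` gives 39 uM, so compound 2 stands level with the only other measured number. Compound 3 `CCC1=C(O)c2c(oc(-c3cc(C)c(C)cc3C)cc2=O)C(CC)(CC)C1=O` carries 2,4,5-trimethylphenyl in place of 3-chloro-4-methylphenyl, on an aromatic carbon next to the ring oxygen: 2,4,5-trimethylphenyl in place of 3-chloro-4-methylphenyl on an aromatic carbon. For the measured compounds named here, the one measured step, a 1.0-fold lower number from compound 1 to compound 2 (0.02 log units; within the scatter), exchanges the aryl group at that same carbon and stays within the scatter. No step beyond the scatter is therefore expected in this assay. The expected step is a 1.1-fold lower number from compound 2 to compound 3 (0.05 log units; within the scatter). For compound 3 the estimated value is 35 uM, with a range of 15 uM to 80 uM.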

Compound 3, concentration for half-maximal effect: 8.2 uM
The estimate for compound 3 lay 4.3-fold (0.63 log units) above the measured number; the measured number lies below the stated range.
By their numbers in this assay, from the lowest: compound 3; then compounds 2 and 1 (each within the scatter of the next).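

In this assay the aryl group on the aromatic carbon next to the ring oxygen proves able to shift the number beyond the scatter, with a 4.8-fold lower number from compound 2 to compound 3 (0.68 log units; beyond the scatter) and a 5.0-fold lower number from compound 1 to compound 3 (0.70 log units; beyond the scatter), which the earlier exchange at that carbon did not show. Of the three aryl groups, only 2,4,5-trimethylphenyl stands apart, and 2-methylphenyl in compound 1 does not give this lower number. Nothing at hand accounts for the drop.

Open, from the compounds shown here alone, is which of the three methyl groups of compound 3 matter. Also open, going by these compounds, is whether methoxy, an amine or a carboxylic acid on that aryl ring would move the number the same way.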